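The source may hold more compounds than are shown below. What is called first, only, known or untested is meant among the compounds shown, and "the series" means these compounds.

Measured so far in a functional assay on WI-38 VA13 cells (Homo sapiens) for cytotoxicity; a lower number here means that less compound is needed, a higher number that more compound is needed for the effect:
- compound 1 `COc1ccccc1C(=O)c1sc2nc(-c3cccs3)ccc2c1N` gives 0.059 ug/mL
- compound 2 `COc1ccc(C(=O)c2sc3nc(-c4cccs4)ccc3c2N)cc1` gives 0.77 ug/mL
- compound 3 `COc1ccc(C(=O)c2sc3nc(-c4cccs4)ccc3c2N)c(OC)c1` gives 0.52 ug/mL

Compound 1 stands lowest of the three numbers in this assay; the nearest is compound 3, reached by an 8.8-fold higher number from compound 1 to compound 3 (0.95 log units; beyond the scatter), and the furthest is compound 2, reached by a 13-fold higher number from compound 1 to compound 2 (1.12 log units; beyond the scatter). Compound 4 `COc1ccc(OC)c(C(=O)c2sc3nc(-c4cccs4)ccc3c2N)c1` differs from compound 1 by methoxy in place of hydrogen on an aromatic carbon; the entering group sits meta to a large group and para to a methoxy group, so the ring of compound 1 keeps its original methoxy and gains a second one.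

Two measured steps add a methoxy to the same ring. One is an 8.8-fold higher number from compound 1 to compound 3 (0.95 log units; beyond the scatter), beyond the scatter. The other is a 1.5-fold lower number from compound 2 to compound 3 (0.17 log units; within the scatter), within the scatter. Neither places the new group at the position used in compound 4, and in compound 3 the two methoxy groups stand in a different arrangement. These steps bear on the change only loosely. Taken together they suggest that a second methoxy tends not to lower the number and can raise it.

For compound 4 the number in this assay is therefore expected to lie above that of compound 1, with the step estimated as a 3.4-fold higher number from compound 1 to compound 4 (0.53 log units; beyond the scatter). The estimate for compound 4 is 0.2 ug/mL, with a range from 0.05 ug/mL to 0.8 ug/mL.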

Compound 4, half-maximal effective concentration: 0.079 ug/mL
Beside the measured number, compound 4's estimate is 2.5-fold (0.40 log units) above it; measured number inside the range.
By their numbers in this assay, from the lowest: compounds 1 and 4 (each within the scatter of the next); then compounds 3 and 2 (each within the scatter of the next).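

In this assay, methoxy in place of hydrogen on the ring of compound 1, meta to a large group and para to a methoxy group, gives a 1.3-fold higher number from compound 1 to compound 4 (0.13 log units; within the scatter), so a second methoxy at this position leaves the number within the scatter. The earlier addition to compound 1 at a different position gave an 8.8-fold higher number from compound 1 to compound 3 (0.95 log units; beyond the scatter), so among these compounds the outcome of adding a second methoxy to compound 1 depends on where the group stands, and the earlier suggestion that it can raise the number holds for compound 3 but not for compound 4. This step also reads alike with the other addition that stays within the scatter: the same change on two cores in this assay, a 1.5-fold lower number (0.17 log units; within the scatter) from compound 2 to compound 3 and a 1.3-fold higher number (0.13 log units; within the scatter) from compound 1 to compound 4, 2.0-fold (0.30 log units) apart, within the scatter of two such steps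

The compounds shown leave open whether this position tolerates only methoxy or also takes an amine, a carboxylic acid or a longer chain such as butoxy without a step beyond the scatter. They also leave open whether the new methoxy would behave the same way on a ring without the original methoxy group of compound 1.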